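Thiophen-3-yl in Place of Phenyl: Compound 4 Expected

This account rests on a few compounds, and the source may have more. Where it says the series, first, only, none or still open, it means among the compounds named here.

Three compounds have been measured in a functional assay on RAW264.7 cells (Mus musculus), read by fluorescence; a higher number here means a weaker inhibitor, a lower number a stronger inhibitor:

Compound 1, `CCOC(=O)C1=CCCCC1S(=O)(=O)Oc1ccc(F)cc1Cl`, gives 904 nM.
Compound 2, `CCOC(=O)C1=CCCCC1S(=O)(=O)Cc1ccccc1`, gives 101 nM.
Compound 3, `CCOC(=O)C1=CCCCC1S(=O)(=O)Cc1cccc(F)c1F`, gives 100 nM.

Compound 2 stands second highest of these three numbers. Its nearest neighbour is compound 3, whose value in this assay lies within the scatter of that of compound 2, so no order between them can be read. For the measured compounds named here, its furthest is compound 1, whose higher number in this assay lies beyond the scatter; no step between these two is recorded, so only the two values themselves speak.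

Compound 4, `CCOC(=O)C1=CCCCC1S(=O)(=O)Cc1ccsc1`, has not yet been measured in this assay. It differs from compound 2 in one place: thiophen-3-yl in place of phenyl on a saturated chain carbon bound to a sulfonyl sulfur. Cut one bond further out, the change reads benzyl to (thiophen-3-yl)methyl.

Going by the values given here, no step between measured compounds is available to gauge this change. Among the compounds with values here, the only nearby comparison is that compound 2 and compound 3 give values within the scatter of each other in this assay. On that basis compound 4 is expected to sit close to compound 2, with a step of a 1.2-fold higher number from compound 2 to compound 4 (0.07 log units; within the scatter) that is estimated not to exceed the scatter in either direction. The estimate for compound 4 in this assay is 120 nM, with a range from 50 nM to 300 nM.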

Compound 4, half-maximal inhibitory concentration: 105 nM
For compound 4 the middle estimate is 1.1-fold (0.06 log units) above the measured one; low and high end bracket the measured number.
By their numbers in this assay, from the lowest: compounds 3, 2 and 4 (each within the scatter of the next); then compound 1.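

In this assay, for the compounds shown here, the replacement of phenyl by thiophen-3-yl on a saturated chain carbon bound to a sulfonyl sulfur gives a 1.0-fold higher number from compound 2 to compound 4 (0.02 log units; within the scatter) and is the first step recorded at this position, so the comparison no longer rests on values alone. The two compounds cannot be put in order, which shows that, for this one pair, a six-membered aromatic ring of carbon only and a five-membered aromatic ring with one hetero atom give values that cannot be told apart, even though the second ring brings sulfur and one hydrogen-bond acceptor by count. No measurement is at hand that could explain this result or assign any role to the sulfur.

This single step says nothing about how far that finding extends, and it remains open whether thiophen-2-yl, pyridin-3-yl or a longer chain such as 2-phenylethyl in place of benzyl would also give a value within the scatter of these compounds. Also open, on these data alone, is whether an amine or a carboxylic acid on the aromatic ring would leave the value in this assay as undisturbed.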